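Adding a third methoxy to compound 2

The compounds below may be only part of what the source reports. "The series", "measured", "known", "first", "only" and "open" are said of these compounds alone.

Measured so far in a functional assay on MCF7 cells (Homo sapiens) for cytotoxicity, read by colorimetric assay and sulforhodamine B assay, with a stated time of 48 h; a higher number here means a weaker inhibitor, a lower number a stronger inhibitor:
compound 1 `COc1ccc(/C=N/n2c(C)nc3c(cnn3-c3ccc(Cl)cc3)c2=O)cc1` gives 38600 nM
compound 2 `COc1ccc(/C=N/n2c(C)nc3c(cnn3-c3ccc(Cl)cc3)c2=O)cc1OC` gives 25000 nM

Compound 2 has the lowest of the two numbers in this assay; its nearest neighbour is compound 1, and a 1.5-fold lower number from compound 1 to compound 2 (0.19 log units; within the scatter) lies within the scatter, so no order between the two is claimed. Compound 3 `COc1cc(/C=N/n2c(C)nc3c(cnn3-c3ccc(Cl)cc3)c2=O)cc(OC)c1OC` differs from compound 2 by one change: methoxy in place of hydrogen on an aromatic carbon. Going by the values given here, the only step that bears on this, a 1.5-fold lower number from compound 1 to compound 2 (0.19 log units; within the scatter), was within the scatter, so in this assay no step beyond the scatter is expected, in either direction; the expected step is a 1.3-fold lower number from compound 2 to compound 3 (0.10 log units; within the scatter). For compound 3 the estimate is 20000 nM, with an expected range of 8000 nM to 50000 nM.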

Compound 3, half-maximal inhibitory concentration: 7600 nM
Compound 3: the middle estimate sits 2.6-fold (0.42 log units) above what was measured; measured number below the stated range.
By their numbers in this assay, from the lowest: compound 3; then compounds 2 and 1 (each within the scatter of the next).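

In this assay, going by these compounds alone, methoxy in place of hydrogen on an aromatic carbon, ortho to a methoxy group and meta to a large group, gives a 3.3-fold lower number from compound 2 to compound 3 (0.52 log units; beyond the scatter) and is the only step beyond the scatter. The earlier methoxy step, a 1.5-fold lower number from compound 1 to compound 2 (0.19 log units; within the scatter), stayed within the scatter, so a methoxy addition on this ring does not always move the number by a readable amount. No measured evidence explains the difference between the two steps. As far as these compounds go, whether a hydroxyl, an amine or a longer chain such as ethoxy at this position would give a similar step remains open.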